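The compounds below may be only part of what the source reports. "The series", "measured", "known", "first", "only" and "open" are said of these compounds alone.

Compound 3 `CCOc1cc2oc(=O)n(CCC(=O)O)c2cc1Cl` gives 1.49 in a physicochemical assay for lipophilicity, read by HPLC, at pH 7.4 (on this read-out lower numbers stand for lower lipophilicity and higher numbers for higher lipophilicity), the second highest of the three numbers measured. Compound 2 `O=C(O)CCn1c(=O)oc2cc(OCc3ccccn3)c(Cl)cc21` gives 1.32, and the step of a number 0.17 log units higher from compound 2 to compound 3 (within the scatter) lies within the scatter. Compound 1 `O=C(O)CCn1c(=O)oc2cc(OCc3ccccc3)c(Cl)cc21` gives 2.71; the step of a number 1.22 log units lower from compound 1 to compound 3 (beyond the scatter) is large, as is a number 1.39 log units lower from compound 1 to compound 2 (beyond the scatter). Compound 4 `CCc1cc2oc(=O)n(CCC(=O)O)c2cc1Cl` carries ethyl in place of ethoxy on an aromatic carbon. Within the data shown here, none of the measured steps bears directly on this change: all three swap the group on the saturated chain carbon bound to the aromatic oxygen, whereas here the oxygen itself leaves and the chain sits directly on the aromatic carbon. Among the measured compounds shown here, with no precedent, only a modest step is expected in this assay, a number 0.36 log units higher from compound 3 to compound 4 (beyond the scatter). Compound 4 is therefore estimated at 1.85, with a range from 1.4 to 2.3.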

Compound 4, distribution coefficient: 1.94
Beside the measured number, compound 4's estimate is 0.09 log units below it; the range from low to high includes it.
By their numbers in this assay, from the lowest: compounds 2 and 3 (each within the scatter of the next); then compound 4; then compound 1.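

In this assay, among these compounds, the first change at the aromatic carbon itself, ethyl in place of ethoxy, gives a number 0.45 log units higher from compound 3 to compound 4 (beyond the scatter), so the ether oxygen at this position can be exchanged with a measurable result. Against the larger ethers, a number 0.62 log units higher from compound 2 to compound 4 (beyond the scatter) and a number 0.77 log units lower from compound 1 to compound 4 (beyond the scatter) place the ethyl compound clearly between the pyridine-bearing ether and the benzyloxy ether. Nothing at hand explains these steps.

On these data alone, how propyl or an amine on this aromatic carbon would read in this assay remains open, as does whether the ethoxy-to-ethyl step holds on another core.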